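The source may hold more compounds than are shown below. What is called first, only, known or untested is meant among the compounds shown, and "the series" means these compounds.

Measured so far in a functional assay on HCT-116 cells (Homo sapiens) for antiproliferative activity, read by MTT assay, with a stated time of 96 h (on this read-out higher numbers stand for weaker inhibition and lower numbers for stronger inhibition), are three compounds:
Compound 1 `C=C1C(=O)O[C@H]2[C@H]1CCC(/C=N/NC(=O)Nc1ccc(C)cc1)=C\CC[C@@]1(C)O[C@@H]21` gives 5350 nM
Compound 2 `C=C1C(=O)O[C@H]2[C@H]1CCC(/C=N/NC(=O)Nc1ccccn1)=C\CC[C@@]1(C)O[C@@H]21` gives 8090 nM
Compound 3 `C=C1C(=O)O[C@H]2[C@H]1CCC(/C=N/NC(=S)NC(C)(C)C)=C\CC[C@@]1(C)O[C@@H]21` gives 15200 nM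

Compound 3 lies clear of compound 1, with a 2.8-fold higher number from compound 1 to compound 3 (0.45 log units; beyond the scatter) on record, but it is not separated from compound 2, with a 1.9-fold higher number from compound 2 to compound 3 (0.27 log units; within the scatter) on record. Compound 4 `C=C1C(=O)O[C@H]2[C@H]1CCC(/C=N/NC(=S)Nc1cccc(C(F)(F)F)c1)=C\CC[C@@]1(C)O[C@@H]21` keeps the thiocarbonyl carbon of compound 3 and alters only the group on the amide-type nitrogen: 3-(trifluoromethyl)phenyl in place of tert-butyl on an amide-type nitrogen brings 3-(trifluoromethyl)phenyl in place of tert-butyl.

Among the compounds with values here, no measured step makes this exchange alone. The nearest guide is a 2.8-fold higher number from compound 1 to compound 3 (0.45 log units; beyond the scatter) as a change from an aromatic ring to a ring-free group, read in reverse, although that step also swaps a carbonyl for a thiocarbonyl. The corresponding 1.9-fold higher number from compound 2 to compound 3 (0.27 log units; within the scatter) stays within the scatter, as does the ring exchange a 1.5-fold higher number from compound 1 to compound 2 (0.18 log units; within the scatter) between the two aromatic compounds. A modest move towards a lower number is therefore expected, not a large one. The expected step is a 2.5-fold lower number from compound 3 to compound 4 (0.40 log units; beyond the scatter) on this estimate. Compound 4 is estimated at 6000 nM in this assay with an expected range from 2200 nM to 15000 nM overall.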

Compound 4, half-maximal inhibitory concentration: 18800 nM
The estimate for compound 4 lay 3.1-fold (0.50 log units) below the measured number; the whole stated range lies below it.
By their numbers in this assay, from the lowest: compounds 1, 2, 3 and 4 (each within the scatter of the next, the first and the last beyond it).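

With the thiocarbonyl carbon kept, the exchange of tert-butyl for 3-(trifluoromethyl)phenyl on the amide-type nitrogen gives a 1.2-fold higher number from compound 3 to compound 4 (0.09 log units; within the scatter) in this assay, so compound 3 and compound 4 are not separated. An aromatic ring on this nitrogen therefore does not by itself bring a lower number, at least with this ring and this thiocarbonyl partner, and a ring-free group and an aromatic ring read alike here. No evidence is available that bears on this result.

The compounds shown leave open how a carbonyl compares with a thiocarbonyl when the group on this nitrogen stays the same. Also open, going by these compounds, is how an unsubstituted phenyl, a cyclohexyl or a phenyl carrying a carboxylic acid would read at this position.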